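This account rests on a few compounds, and the source may have more. Where it says the series, first, only, none or still open, it means among the compounds named here.

Measured compounds in a functional assay on MCF7 cells (Homo sapiens) for cytotoxicity, read by MTT assay, with a stated time of 24 h; a lower number here means a stronger inhibitor, a higher number a weaker inhibitor:
compound 1 `Cc1ccc2oc(-c3ccc(NC(=O)CN4CCN(CCN(C)C)CC4)c(C)c3)nc2c1` gives 90300 nM
compound 2 `Cc1cc(-c2nc3cc(F)ccc3o2)ccc1NC(=O)CCl` is reported only as a limit of this assay, > 100000 nM
compound 3 `Cc1cc(-c2nc3ccccc3o2)ccc1NC(=O)CCl` gives 29800 nM

Compound 3 has the lowest of the two numbers; the nearest number is that of compound 1, and it sits beyond the scatter above compound 3. Compound 2 returns only a limit of this assay, as recorded in the limit of > 100000 nM in this assay, at which 1 of the 3 values shown sits.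

Compound 4 `Cc1cc(-c2nc3cc(Cl)ccc3o2)ccc1NC(=O)CCl` is not yet measured in this assay. It differs from compound 3 in one place: chloro in place of hydrogen on an aromatic carbon.

Among the measured compounds shown here, one measured step bears on this change, because it also concerns a halogen on an aromatic carbon of the shared core: an at least 3.3-fold lower number from compound 2 to compound 3 (0.52 log units; beyond the scatter). That step went from a limit to a number when fluoro was replaced by hydrogen. Adding chloro at the place described runs the other way, and the same kind of halogen on the same core is the only guide available; the expectation is therefore a higher number for compound 4, of at least modest size, with a real chance that this assay again reports only a limit.

Compound 4 is estimated at 70000 nM, within a range from 25000 nM to 200000 nM, which corresponds to an expected step of a 2.3-fold higher number from compound 3 to compound 4 (0.37 log units; beyond the scatter).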

Compound 4, half-maximal inhibitory concentration: > 100000 nM
Compound 4 ended at the assay's limit; the forecaster's own chance of this, stated with the estimate: 35%; middle value at least 1.4-fold (0.15 log units) away from the limit.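

In this assay, chloro in place of hydrogen on an aromatic carbon brings an at least 3.3-fold higher number from compound 3 to compound 4 (0.52 log units; beyond the scatter). Among the compounds shown here, until this result, only fluoro had been seen at this place on the shared core; now a second halogen also separates from hydrogen, and of the three compounds that vary here, compound 3, which carries hydrogen, is the only one to return a number. Compound 2 and compound 4 both stand at a limit rather than a number, and the step between them cannot be read, so fluoro and chloro cannot be put in order: the limit of > 100000 nM in this assay, at which 2 of the 4 values shown sit.

On these data alone, the compounds that differ only at this place carry hydrogen, fluoro or chloro there, so it remains open how a methoxy group, a bromo group or an amine at the same carbon would read, and whether any of them would give a number lower than that of compound 3. Also open, as far as these compounds go, is whether chloro in place of hydrogen would bring a similar step on a compound with the longer amine-bearing side chain of compound 1.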